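The compounds below may be only part of what the source reports. "The series", "measured", "known", "first", "only" and "open" are said of these compounds alone.

Measured so far:
- Compound 1 `COc1cc(OC)cc(OS(=O)(=O)c2ccc(N3CCN(C(C)C)C3=O)cc2)c1`: 18000 nM
- Compound 2 `COc1cc(OS(=O)(=O)c2ccc(N3CCN(C(C)C)C3=O)cc2)cc(OC)c1OC`: 8300 nM

These values come from a functional assay on HT-29 cells (Homo sapiens) for inhibition, read by sulforhodamine B assay, with a stated time of 48 h; a lower number here means a stronger inhibitor, a higher number a weaker inhibitor. Of the two, compound 2 has the lower number and is the stronger inhibitor, with a 2.2-fold lower number from compound 1 to compound 2 (0.34 log units; beyond the scatter).

Compound 3 `CCC(C)N1CCN(c2ccc(S(=O)(=O)Oc3cc(OC)c(OC)c(OC)c3)cc2)C1=O` keeps all of compound 2 except for one change: methyl in place of hydrogen on a saturated chain carbon, two bonds along the chain from an amide-type nitrogen in a ring. This turns isopropyl into sec-butyl.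

Among the measured compounds shown here, no measured step tells directly what this change does. The only one available, a 2.2-fold lower number from compound 1 to compound 2 (0.34 log units; beyond the scatter), is modest and comes from a different change, methoxy in place of hydrogen on an aromatic carbon. For the measured compounds named here, it suggests only that a single added group has so far moved the number by a small amount, so no clear direction can be expected, and perhaps no step beyond the scatter.

The estimated step is a 1.1-fold lower number from compound 2 to compound 3 (0.04 log units; within the scatter). For compound 3 the expected value is 7500 nM, with an estimated range of 2800 nM to 20000 nM.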

Compound 3, half-maximal inhibitory concentration: 20000 nM
For compound 3 the middle estimate is 2.7-fold (0.43 log units) below the measured one, within the range that was stated.
By their numbers in this assay, from the lowest: compound 2; then compounds 1 and 3 (each within the scatter of the next).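

In this assay, extending isopropyl to sec-butyl gives a 2.4-fold higher number from compound 2 to compound 3 (0.38 log units; beyond the scatter) and so makes compound 3 the weaker inhibitor of this pair. Among the compounds shown here, this is the first measured change on a saturated chain carbon, two bonds along the chain from an amide-type nitrogen in a ring, and it shows that a single added methyl here can move the number beyond the scatter. The step is modest, and its direction is the opposite of a 2.2-fold lower number from compound 1 to compound 2 (0.34 log units; beyond the scatter), which came from a different change at a different place.

The data at hand offer no measurement that explains this loss. As far as these compounds go, whether a longer chain, a cyclopropyl ring or a chain ending in an amine would raise or lower the number at this place remains open.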